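The source may hold more compounds than are shown below. What is called first, only, known or untested is meant among the compounds shown, and "the series" means these compounds.

Compound 2 `Nc1nc(=O)ccn1[C@@H]1O[C@H](COP(=O)(O)O)[C@@H](O)[C@H]1O`: in an in vitro functional assay on 1321-N1 cells for agonist activity at P2Y purinoceptor 4 (Homo sapiens), read by scintillation proximity assay and inositol phosphate accumulation (on this read-out lower numbers stand for an effect already at smaller amounts and higher numbers for an effect only at larger amounts of compound), compound 2 gives 4980 nM.
Compound 1 `CNc1nc(=O)ccn1[C@@H]1O[C@H](COP(=O)(O)O)[C@@H](O)[C@H]1O`: in this assay compound 1 gives only > 100000 nM, which is a limit rather than a number (the limit of > 100000 nM in this assay, at which 1 of the 2 values shown sits).

For the measured compounds named here, compound 2 therefore stands as the only value that is a number; the other is a limit. Compound 3 `O=c1ccn([C@@H]2O[C@H](COP(=O)(O)O)[C@@H](O)[C@H]2O)c(SCCc2ccccc2)n1` differs from compound 2 by phenethylsulfanyl in place of amino on an aromatic carbon. Going by the values given here, the one measured step, an at least 20-fold lower number from compound 1 to compound 2 (1.30 log units; beyond the scatter), altered the same amino group and was large. Among the compounds with values here, the change to compound 3 is far bigger than that step, and no measured step tests a group of this kind, so the expectation rests on weak ground. Compound 3 is estimated at 30000 nM (range 3000 nM to 150000 nM), an expected step of a 6.0-fold higher number from compound 2 to compound 3 (0.78 log units; beyond the scatter) toward a higher number.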

Compound 3, half-maximal effective concentration: > 100000 nM
Compound 3 ended at the assay's limit; the forecaster's own chance of this, stated with the estimate: 45%; middle value at least 3.3-fold (0.52 log units) from the limit.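

In this assay, for the compounds shown here, the aromatic carbon between two ring nitrogen atoms tolerates the large phenethylsulfanyl no better than the methylated amino group: replacing amino by phenethylsulfanyl gives an at least 20-fold higher number from compound 2 to compound 3 (1.30 log units; beyond the scatter) and leaves compound 2 as the only compound with a number. Both changes shown at this amino group therefore go the same way. Compound 3 gives a limit rather than a number, as compound 1 does, and the step between them cannot be read: the limit of > 100000 nM in this assay, at which 2 of the 3 values shown sit.

From the compounds shown here alone, whether a small methylsulfanyl, a hydroxyl or an ethylamino group on this carbon would still give a number remains open. Also open, going by these compounds, is whether the sulfur or the phenethyl chain accounts for the change.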